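Swapping a sulfanyl arm for cyclopentyloxy on the shared core

This account rests on a few compounds, and the source may have more. Where it says the series, first, only, none or still open, it means among the compounds named here.

Compound 1, `Cc1cc(F)c(S(C)(=O)=O)cc1C(=O)N=C(N)N`: 44 nM
Compound 2, `Cc1cc(Sc2ccccc2Cl)c(S(C)(=O)=O)cc1C(=O)N=C(N)N`: 14 nM

In a functional assay for inhibition of sodium/hydrogen exchanger (Oryctolagus cuniculus) (on this read-out higher numbers stand for weaker inhibition and lower numbers for stronger inhibition), compound 1 gives 44 nM and compound 2 gives 14 nM. Among the measured compounds shown here, compound 2 stands at the lowest number of the two, so it is the stronger inhibitor, and the single measured step is a 3.1-fold lower number from compound 1 to compound 2 (0.50 log units; beyond the scatter). Compound 3, `Cc1cc(OC2CCCC2)c(S(C)(=O)=O)cc1C(=O)N=C(N)N`, has not yet been measured. It differs from compound 2 in one place: cyclopentyloxy in place of (2-chlorophenyl)sulfanyl on an aromatic carbon. For the measured compounds named here, the one step that bears on this place is a 3.1-fold lower number from compound 1 to compound 2 (0.50 log units; beyond the scatter), where a small fluoro gave way to a larger group and the number fell. Going by the values given here, no measured step involves cyclopentyloxy itself, so the direction of the new change is uncertain. The expected step is a 1.8-fold higher number from compound 2 to compound 3 (0.25 log units; within the scatter), a move toward a somewhat higher number that may not exceed the scatter. Compound 3 is therefore estimated at 25 nM, with a range from 8 nM to 80 nM.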

Compound 3, half-maximal inhibitory concentration: 27 nM
The estimate for compound 3 lay 1.1-fold (0.03 log units) below the measured number; low and high end bracket the measured number.
By their numbers in this assay, from the lowest: compounds 2, 3 and 1 (each within the scatter of the next, the first and the last beyond it).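

Cyclopentyloxy, a non-aromatic ring attached through oxygen, can take the place of (2-chlorophenyl)sulfanyl, an aromatic ring attached through sulfur, with no change that can be told apart from scatter (a 1.9-fold higher number from compound 2 to compound 3 (0.29 log units; within the scatter)). The same holds when it is compared with the small fluoro (a 1.6-fold lower number from compound 1 to compound 3 (0.21 log units; within the scatter)), so among these three compounds only compound 1 and compound 2 stand apart beyond the scatter. No outside measurement offers an explanation for these numbers.

Because the linking atom and the ring both differ between compound 2 and compound 3, these compounds cannot show which of the two matters; a phenoxy group or a plain cyclopentylsulfanyl group would separate them. As far as these compounds go, it also remains open whether an amine or a carboxylic acid at this aromatic carbon would shift the number beyond the scatter.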